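The compounds below may be only part of what the source reports. "The series", "measured", "known", "first", "only" and "open" are said of these compounds alone.

Working notes on the series. For the measured compounds named here, in a functional assay on B16 cells (Mus musculus) for inhibition (on this read-out lower numbers stand for stronger inhibition and higher numbers for weaker inhibition), compound 1 (`CC(C)CN(CC(=O)N(CC(C)C)NC(=O)OCc1ccccc1)NC(=O)CBr`) gives 3300 nM as the second highest of the three numbers so far. Compound 2 (`CC(C)CN(NC(=O)OCc1ccccc1)C(=O)CN(Cc1ccccc1)NC(=O)CBr`) gives 1800 nM and is not separated from compound 1, since the measured step (a 1.8-fold lower number from compound 1 to compound 2 (0.26 log units; within the scatter)) lies within the scatter. Compound 3 (`CC(C)CN(CC(=O)NN(Cc1ccccc1)c1cnccn1)NC(=O)CBr`) gives 14800 nM as the highest of the three numbers.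

Compound 4 (`CC(C)CN(CC(=O)N(CC(C)C)NC(=O)OCc1ccccc1)NC(=O)CNNC(=O)CBr`) has not been measured. It departs from compound 1 by a single change (a group of 6 heavy atoms (2 carbon, 2 nitrogen, 1 oxygen, 1 bromine; no ring) in place of one bromine atom, on a saturated chain carbon bound to a carbonyl carbon) in which a group with no ring replaces one bromine atom on a saturated chain carbon bound to a carbonyl carbon.

Going by the values given here, no measured step touches this place. Among the compounds with values here, the only single-place step (a 1.8-fold lower number from compound 1 to compound 2 (0.26 log units; within the scatter)) concerns phenyl in place of isopropyl on a saturated chain carbon bound to an amine nitrogen, so it offers little guidance. Only a loose expectation follows: a modest step toward a higher number in this assay is expected, with no change beyond the scatter also possible. The expected middle is taken from the span between compound 1 (3300 nM) and compound 3 (14800 nM) and stays close to the former.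

The estimate implies an expected step (a 1.8-fold higher number from compound 1 to compound 4 (0.26 log units; within the scatter)) of modest size. For compound 4 the estimated value is 6000 nM with an expected range from 1500 nM to 25000 nM in this estimate.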

Compound 4, half-maximal inhibitory concentration: 2300 nM
The estimate for compound 4 lay 2.6-fold (0.42 log units) above the measured number; low and high end bracket the measured number.
By their numbers in this assay, from the lowest: compounds 2, 4 and 1 (each within the scatter of the next); then compound 3.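

For the compounds shown here, this is the first measured change at the saturated chain carbon bound to a carbonyl carbon. In this assay the group of 6 heavy atoms in place of one bromine atom gives a step within the scatter (a 1.4-fold lower number from compound 1 to compound 4 (0.16 log units; within the scatter)), so this larger group, with its 2 hydrogen-bond donors and 2 hydrogen-bond acceptors, does not separate the pair on this read-out. The entering group itself carries 1 bromine, so the pair shows that this place accepts a longer group with no ring when a bromine remains at its end, and nothing on hand gives a reason for this result.

All four compounds shown carry a bromine at this end of the molecule, so the part played by that atom stays open, and an acetyl end without bromine, or an amine or a carboxylic acid at this place, would address it. Going by these compounds alone, it also stays open whether the same group in place of the bromine atom would give a similar result on the core of compound 2 or compound 3, since the only step read at this place rests on the core of compound 1.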